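The source may report more compounds than this note shows. Statements on the series, on what has been measured and on what is new or still open speak of the compounds shown alone.

Measured so far:
Compound 1 `Cc1ccc(-c2c(C)nc(C(=O)N(C)Cc3ccccc3)c(C)c2C(OC(C)(C)C)C(=O)O)cc1C`, which in an ADME assay on MT4 cells (Homo sapiens) for cytotoxicity, read by MTT assay (a lower number here means that less compound is tolerated, a higher number that more compound is tolerated), gives 77000 nM.
Compound 2 `COc1ccc(Nc2nc(C)c(-c3ccc(C)c(C)c3)c(C(OC(C)(C)C)C(=O)O)c2C)cc1`, which in this assay gives 28000 nM.

Of the two numbers, compound 2 has the lower one; its nearest neighbour is compound 1, and the step of a 2.8-fold lower number from compound 1 to compound 2 (0.44 log units; beyond the scatter) was modest but beyond the scatter.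

Compound 3 `Cc1ccc(-c2c(C)nc(NC(=O)Nc3ccccc3)c(C)c2C(OC(C)(C)C)C(=O)O)cc1C` is not yet measured in this assay. It differs from compound 2 in one place: phenylcarbamoyl in place of 4-methoxyphenyl on a nitrogen on an aromatic ring. Among the compounds with values here, the only measured step that bears on this is the one from compound 1 to compound 2, which exchanged a benzyl(methyl)carbamoyl group for a (4-methoxyphenyl)amino group and lowered the number modestly. Compound 3 brings a carbonyl and an amide hydrogen back in at that position while keeping the anilino-type linkage, so it sits between the two measured compounds in kind. The expectation is therefore a small step back up, a 1.6-fold higher number from compound 2 to compound 3 (0.21 log units; within the scatter), but one that may well stay within the scatter. Compound 3 is estimated at 45000 nM, with a range from 18000 nM to 120000 nM.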

Compound 3, half-maximal cytotoxic concentration: 9900 nM
The estimate for compound 3 lay 4.5-fold (0.66 log units) above the measured number; measured number outside the range, below it.
By their numbers in this assay, from the lowest: compound 3; then compound 2; then compound 1.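

In this assay, putting phenylcarbamoyl in place of 4-methoxyphenyl on a nitrogen on an aromatic ring did not return the number upward, and the urea-type (phenylcarbamoyl)amino group instead gave the lowest number of the series, a modest step that lies beyond the scatter (a 2.8-fold lower number from compound 2 to compound 3 (0.45 log units; beyond the scatter)). Set against the benzyl(methyl)carbamoyl group on an aromatic carbon, the same group gives the widest step seen at this position so far (a 7.8-fold lower number from compound 1 to compound 3 (0.89 log units; beyond the scatter)), so a carbonyl at this position does not by itself go with the higher number: compound 1 and compound 3 both carry one, yet they stand at the two ends of the series. No measurement shown here accounts for the fall in the number, so the reason for it remains unknown.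

The compounds shown leave open whether the lower number belongs to the terminal phenyl ring of compound 3 or to the urea-type linkage itself. An acetyl group on the same nitrogen, or a cyclohexyl ring in place of that phenyl ring, would separate the two, and all three numbers rest on a single shared core.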